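From methylsulfanyl to difluorophenyl on a shared core

A few compounds are considered here, and "the series" means these few. Any claim that something is new, unique, unknown or untested is made for them only; others in the source may bear on it.

In a functional assay on DU-145 cells (Homo sapiens) for inhibition, read by trypan blue exclusion, with a stated time of 96 h (on this read-out lower numbers stand for stronger inhibition of growth and higher numbers for weaker inhibition of growth), compound 1 `CSc1ccc(/C=C(/Sc2ccc(C)cc2)C(=O)c2ccc(Br)cc2)cc1` gives 50000 nM, level with compound 3 `Cc1ccc(S/C(=C/c2ccc(-c3ccccc3)cc2)C(=O)c2ccc(Br)cc2)cc1` at 50000 nM, while compound 2 `Cc1ccc(S/C(=C/c2ccc(Oc3ccccc3)cc2)C(=O)c2ccc(Br)cc2)cc1` gives 1000 nM. Compound 4 `Cc1ccc(S/C(=C/c2ccc(F)cc2F)C(=O)c2ccc(Br)cc2)cc1` carries 2,4-difluorophenyl in place of 4-(methylsulfanyl)phenyl on a double-bonded chain carbon bound to a double-bonded chain carbon. For the measured compounds named here, two measured steps bear on this change, though neither brings in fluorine. The step of a 50-fold lower number from compound 1 to compound 2 (1.70 log units; beyond the scatter) is large, whereas the step of no change at the digits printed from compound 1 to compound 3 (within the scatter) lies within the scatter. A moderate move toward stronger inhibition of growth is therefore expected, namely a 4.2-fold lower number from compound 1 to compound 4 (0.62 log units; beyond the scatter). For compound 4 the estimated value is 12000 nM, with an expected range from 2000 nM to 50000 nM.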

Compound 4, concentration for 50% growth inhibition: > 100000 nM
Compound 4: a limit, no number; the forecaster's own chance of this, stated with the estimate: 15%; middle value at least 8.3-fold (0.92 log units) from the limit.
By their numbers in this assay, from the lowest: compound 2; then compounds 1 and 3 (each within the scatter of the next). At a limit, above all of these: compound 4.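

In this assay compound 4 gives > 100000 nM as a limit of the assay and not a number. The step of an at least 2.0-fold higher number from compound 1 to compound 4 (0.30 log units; that floor lies within the scatter) therefore offers only a floor, yet it shows that 2,4-difluorophenyl on this double-bonded chain carbon brings no lower number. The gain seen in the step of a 50-fold lower number from compound 1 to compound 2 (1.70 log units; beyond the scatter) thus does not carry over to this change. On these data alone, how far compound 4 lies past its limit stays open, as does how a phenyl ring bearing an amine or a carboxylic acid would read at this place.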